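The source may report more compounds than this note shows. Statements on the series, on what has been measured and on what is new or still open speak of the compounds shown alone.

Measured so far in a physicochemical assay for lipophilicity; on this read-out higher numbers stand for higher lipophilicity and lower numbers for lower lipophilicity:
compound 1 `CCOC(=O)C1=C(C)N=C(C)/C(=C(/O)OCC)C1c1cccc(OC)c1`: 3.22
compound 2 `CCOC(=O)C1=C(C)NC(C)=C(C(=O)OCC)C1c1cccc(O)c1`: 4.03
compound 3 `CCO/C(O)=C1\C(C)=NC(C)=C(C(=O)OC)C1c1ccc([N+](=O)[O-])cc1`: 3.6

Compound 1, at 3.22, stands lowest of these three in this assay, and both gaps to the others lie beyond the usual scatter. Compound 3 is the nearest at 3.6, and compound 2 is the furthest at 4.03.

Compound 4 `CCOC(=O)C1=C(C)N=C(C)/C(=C(/O)OCC)C1c1ccccc1OC` has not yet been measured. It has the same atoms as compound 1, joined differently: 2-methoxyphenyl in place of 3-methoxyphenyl on a saturated ring carbon. In words, 2-methoxyphenyl stands in place of 3-methoxyphenyl on a saturated ring carbon, and the rest of the structure stays as it is. Within the data shown here, no two measured compounds differ in one place only, so the data hold no direct measure of such a change. The group that leaves and the group that enters have the same counts, so no shift in either direction is expected beyond the scatter. The anchor for the expectation is therefore compound 1 at 3.22. The expected change is small, namely a number 0.03 log units higher from compound 1 to compound 4 (within the scatter), and it is expected to stay within the scatter. For compound 4 the estimated value is 3.25, with an expected range from 2.8 to 3.7.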

Compound 4, partition coefficient: 3.19
For compound 4 the middle estimate is 0.06 log units above the measured one, and the stated range covers the measured number.
By their numbers in this assay, from the lowest: compounds 4 and 1 (each within the scatter of the next); then compound 3; then compound 2.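

In this assay, this is the first pair among the compounds shown that differs in one place only, and it gives a direct reading of 2-methoxyphenyl in place of 3-methoxyphenyl on a saturated ring carbon of the shared core: a number 0.03 log units lower from compound 1 to compound 4 (within the scatter). The earlier compounds shown here offered no such reading, as each differed from the others in more than one place. Here, two groups with the same heavy atoms and the same counts of hydrogen-bond donors and acceptors give numbers that this read-out cannot tell apart at this position, and nothing measured here bears on why the two numbers lie so close.

On these data alone, whether an amine, a carboxylic acid or a longer chain such as butoxy, standing on the phenyl ring in place of the methoxy group, would give a step beyond the scatter remains open. As far as these compounds go, it is also open whether the same exchange of 3-methoxyphenyl for 2-methoxyphenyl would read alike on a core with other ester groups, as this single pair speaks for the core of compound 1 alone.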